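A few compounds are considered here, and "the series" means these few. Any claim that something is new, unique, unknown or untested is made for them only; others in the source may bear on it.

Compound 1 `FC(F)(F)c1ccc(CSc2nc(Nc3ccccc3)c3ccccc3n2)cc1` gives 20000 nM in a functional assay on PC-3 cells (Homo sapiens) for cytotoxicity, read by MTT assay, with a stated time of 72 h; a lower number here means a stronger inhibitor, a higher number a weaker inhibitor.
Compound 2 `COc1ccccc1Nc1nc(SCc2ccc(C(F)(F)F)cc2)nc2ccccc12` gives 14100 nM in this assay.
Compound 3 `O=[N+]([O-])c1cccc(Nc2nc(SCc3ccc(C(F)(F)F)cc3)nc3ccccc23)c1` gives 13500 nM in this assay.

Among these three numbers compound 2 stands second highest. Its nearest neighbour is compound 3, reached by the step of a 1.0-fold lower number from compound 2 to compound 3 (0.02 log units; within the scatter), and its furthest is compound 1, from which the step of a 1.4-fold lower number from compound 1 to compound 2 (0.15 log units; within the scatter) leads to compound 2. The third measured step, a 1.5-fold lower number from compound 1 to compound 3 (0.17 log units; within the scatter), also lies within the scatter, so the three compounds cannot be told apart on these data.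

Compound 4 `O=[N+]([O-])c1ccc(Nc2nc(SCc3ccc(C(F)(F)F)cc3)nc3ccccc23)cc1` differs from compound 2 by 4-nitrophenyl in place of 2-methoxyphenyl on a nitrogen on an aromatic ring. Going by the values given here, the steps that bear on this change are a 1.0-fold lower number from compound 2 to compound 3 (0.02 log units; within the scatter), in which a nitro-bearing phenyl likewise replaced the 2-methoxyphenyl, together with a 1.4-fold lower number from compound 1 to compound 2 (0.15 log units; within the scatter) and a 1.5-fold lower number from compound 1 to compound 3 (0.17 log units; within the scatter). None of them moved the number beyond the scatter. Among the compounds with values here, no measured step separates a 3-nitrophenyl from a 4-nitrophenyl on this nitrogen, so no direction can be read for that part of the change. The expected step in this assay is therefore none beyond the scatter, a 1.0-fold lower number from compound 2 to compound 4 (0.02 log units; within the scatter). Compound 4 is estimated at 13500 nM in this assay, with a range from 6000 nM to 30000 nM.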

Compound 4, half-maximal inhibitory concentration: 7900 nM
Compound 4: the middle estimate sits 1.7-fold (0.23 log units) above what was measured; measured number inside the range.
By their numbers in this assay, from the lowest: compounds 4, 3, 2 and 1 (each within the scatter of the next, the first and the last beyond it).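

In this assay, a 2.5-fold lower number from compound 1 to compound 4 (0.40 log units; beyond the scatter) is the first step among these compounds to pass the scatter, so the 4-nitrophenyl on this nitrogen can be told apart from the plain phenyl, although the separation is only modest. The other two steps, a 1.8-fold lower number from compound 2 to compound 4 (0.25 log units; within the scatter) and a 1.7-fold lower number from compound 3 to compound 4 (0.23 log units; within the scatter), stay within the scatter, so the 4-nitrophenyl cannot be distinguished from either the 2-methoxyphenyl or the 3-nitrophenyl, and nothing can be said for or against a difference between the two nitrophenyl groups. Nothing available offers an explanation for the step that passes the scatter.

The compounds shown leave open whether another group on this phenyl ring, such as an amine or a carboxylic acid, would lower the number further than the nitro group does. They also leave open whether the modest step would persist if the rest of the shared core were changed, since all four compounds differ only in the aromatic group on this nitrogen.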